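Swapping a cyclopentyl amide for a chloropyrimidine amide

The compounds below may be only part of what the source reports. "The series", "measured", "known", "first", "only" and "open" are said of these compounds alone.

Of the compounds shown here, three sharing one core have been measured in a functional assay on isolated protein for inhibition of Glucose-dependent insulinotropic receptor (Rattus norvegicus), read by HTRF and cAMP accumulation; on this read-out higher numbers stand for an effect only at larger amounts of compound and lower numbers for an effect already at smaller amounts. Compound 1 `Cc1nc(S(C)(=O)=O)ccc1Oc1ncnc(OC2CCN(C(=O)O[C@H](C)CF)CC2)c1F` gives 1520 nM, compound 2 `Cc1nc(S(C)(=O)=O)ccc1Oc1ncnc(OC2CCN(C(=S)OC3(C)CC3)CC2)c1F` gives 48.8 nM, and compound 3 `Cc1nc(S(C)(=O)=O)ccc1Oc1ncnc(OC2CCN(C(=O)C3CCCC3)CC2)c1F` gives 407 nM. On these numbers compound 3 stands second highest of the three: its nearest neighbour is compound 1, and the distance is a 3.7-fold lower number from compound 1 to compound 3 (0.57 log units; beyond the scatter), while its furthest neighbour is compound 2, and that distance is an 8.3-fold higher number from compound 2 to compound 3 (0.92 log units; beyond the scatter) in the opposite sense.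

Compound 4 `Cc1nc(S(C)(=O)=O)ccc1Oc1ncnc(OC2CCN(C(=O)c3ncc(Cl)cn3)CC2)c1F` differs from compound 3 in one place: 5-chloropyrimidin-2-yl in place of cyclopentyl on a carbonyl carbon. Among the measured steps, the two that change the group on the carbonyl carbon or on the ring nitrogen are a 3.7-fold lower number from compound 1 to compound 3 (0.57 log units; beyond the scatter) and an 8.3-fold higher number from compound 2 to compound 3 (0.92 log units; beyond the scatter); both are modest, and neither swaps a saturated ring for an aromatic one, so they inform only the likely size, not the direction. For compound 4 the expected step is a 1.6-fold lower number from compound 3 to compound 4 (0.21 log units; within the scatter), a modest shift within this assay. Compound 4 is therefore estimated at 250 nM, with a range from 60 nM to 1200 nM.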

Compound 4, half-maximal effective concentration: 30.9 nM
Beside the measured number, compound 4's estimate is 8.1-fold (0.91 log units) above it; measured number outside the range, below it.
By their numbers in this assay, from the lowest: compounds 4 and 2 (each within the scatter of the next); then compound 3; then compound 1.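

Placing 5-chloropyrimidin-2-yl on the carbonyl carbon in place of cyclopentyl gives the first large step at this position between two amides (a 13-fold lower number from compound 3 to compound 4 (1.12 log units; beyond the scatter)), so the choice of ring here matters a great deal in this assay. The same compound also reaches the level of the thiocarbamate-bearing compound 2 (a 1.6-fold lower number from compound 2 to compound 4 (0.20 log units; within the scatter)), and the gain over the group on compound 1 is larger still (a 49-fold lower number from compound 1 to compound 4 (1.69 log units; beyond the scatter)), showing that a thiocarbonyl is not needed for a low number. Nothing measured here explains why the aromatic ring does so much better.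

Still open, from the compounds shown here alone, is whether the gain comes from the chlorine, from the ring nitrogens or from the aromatic ring itself. Phenyl, unsubstituted pyrimidin-2-yl and 5-methylpyrimidin-2-yl on the same carbonyl carbon would begin to separate these.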